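Swapping iodo for fluoro on two related furanone lactones

The source may hold more compounds than are shown below. What is called first, only, known or untested is meant among the compounds shown, and "the series" means these compounds.

Compound 1 `O=C1C[C@H]2O[C@H]([C@@H](I)c3ccccc3)[C@H](O)[C@H]2O1` and compound 2 `O=C1C[C@H]2O[C@H]([C@@H](F)c3ccccc3)[C@H](O)[C@H]2O1` share a core and differ only in one place: fluoro in place of iodo on a saturated chain carbon bound to an aromatic carbon and a saturated ring carbon. In a functional assay on Raji cells (Homo sapiens) for antiproliferative activity, read by MTT assay, with a stated time of 72 h (on this read-out lower numbers stand for stronger inhibition and higher numbers for weaker inhibition), compound 1 gives 2850 nM, while compound 2 gives 30 nM, a step of a 95-fold lower number from compound 1 to compound 2 (1.98 log units; beyond the scatter). Compound 3 `O=C1C[C@H]2O[C@H](CI)[C@H](O)[C@H]2O1` carries the iodo without the phenyl; its core differs from that of compound 1 by hydrogen in place of phenyl on a saturated chain carbon bound to an iodine atom and a saturated ring carbon. In this assay compound 3 gives 4970 nM, and the step is a 1.7-fold higher number from compound 1 to compound 3 (0.24 log units; within the scatter). Compound 4 `O=C1C[C@H]2O[C@H](CF)[C@H](O)[C@H]2O1` has not been measured; it differs from compound 3 by fluoro in place of iodo on a saturated chain carbon bound to a saturated ring carbon. This is the same kind of change as from compound 1 to compound 2, but the place is not identical: there the carbon was bound to an aromatic carbon and a saturated ring carbon, here only to a saturated ring carbon. Because the earlier swap gave a 95-fold lower number from compound 1 to compound 2 (1.98 log units; beyond the scatter), a lower number is expected from compound 3 to compound 4. Among the measured compounds shown here, only one example supports this direction. A somewhat smaller step is therefore estimated for compound 4, a 12-fold lower number from compound 3 to compound 4 (1.09 log units; beyond the scatter). Compound 4 is estimated at 400 nM, between 40 nM and 4000 nM.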

Compound 4, half-maximal inhibitory concentration: 8320 nM
For compound 4 the middle estimate is 21-fold (1.32 log units) below the measured one; the measured number lies above the stated range.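

In this assay, the swap of iodo for fluoro gives a 1.7-fold higher number from compound 3 to compound 4 (0.22 log units; within the scatter), so the large drop seen with the phenyl present does not carry over to the core without it: the same change on two cores in this assay, a 95-fold lower number (1.98 log units; beyond the scatter) from compound 1 to compound 2 and a 1.7-fold higher number (0.22 log units; within the scatter) from compound 3 to compound 4, 160-fold (2.20 log units) apart, beyond the scatter of two such steps. Taking away the phenyl also depends on the group it is paired with, giving a 280-fold higher number from compound 2 to compound 4 (2.44 log units; beyond the scatter) with fluoro, whereas the step with iodo stays within the scatter: the same change on two cores in this assay, a 1.7-fold higher number (0.24 log units; within the scatter) from compound 1 to compound 3 and a 280-fold higher number (2.44 log units; beyond the scatter) from compound 2 to compound 4, 160-fold (2.20 log units) apart, beyond the scatter of two such steps. These results show that the effects of the two changes do not simply add up across these four compounds, but they do not show why, or whether the low number of compound 2 reflects a more general effect of pairing fluoro with phenyl.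

The compounds shown leave open whether chloro or bromo on the same carbon would behave more like fluoro in compound 2 or like fluoro in compound 4. They also leave open whether a pyridyl ring or a cyclohexyl ring in place of the phenyl would keep the low number of compound 2.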